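The source may hold more compounds than are shown below. What is called first, only, known or untested is meant among the compounds shown, and "the series" means these compounds.

Measured compounds in an ADME assay on L6 cells (Rattus norvegicus) for cytotoxicity, read by resazurin assay, with a stated time of 70 h; on this read-out higher numbers stand for weaker inhibition and lower numbers for stronger inhibition:
Compound 1, `COc1cc(NC(C)CCCNC(=O)/C=C/c2ccc(C(F)(F)F)cc2)c2ncccc2c1`, gives 160000 nM.
Compound 2, `COc1cc(NC(C)CCCNC(=O)NCCNC(c2ccccc2)(c2ccccc2)c2ccccc2)c2ncccc2c1`, gives only a limit, > 171000 nM.
Compound 3, `COc1cc(NC(C)CCCNC(=O)NNC(=O)/C=C/c2ccccc2)c2ncccc2c1`, gives 13900 nM.

Of the compounds shown here, three sharing one core have been tested in this assay. Of the two values that are numbers, compound 3 holds the lower one; compound 1 sits higher by a margin beyond the usual scatter. The remaining entry is the limit noted for compound 2 (the limit of > 171000 nM in this assay, at which 1 of the 3 values shown sits), which gives no number to compare against.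

The next compound, compound 4, `COc1cc(NC(C)CCCNC(=O)NNC(=O)N(CCO)CCO)c2ncccc2c1`, has not yet been measured in this assay. It differs from compound 3 in one place: bis(2-hydroxyethyl)amino in place of 2-phenylethenyl on a carbonyl carbon. For the measured compounds named here, no pair of measured compounds differing in a single place is available, so the size of this step cannot be read off from measured neighbours. Both compounds that carry no hydroxyethyl groups, compound 1 and compound 2, sit at high numbers or at the limit, while compound 3 sits lowest; on that basis the account expects the number for compound 4 to move upward, a step of a 5.0-fold higher number from compound 3 to compound 4 (0.70 log units; beyond the scatter), away from the low value of compound 3. Compound 4 is therefore estimated at 70000 nM, with a plausible range from 20000 nM to 200000 nM, and the measured value may turn out to be reported only as a limit.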

Compound 4, half-maximal inhibitory concentration: 178000 nM
Compound 4: middle estimate off by 2.5-fold (0.41 log units), on the low side; the measured number falls inside the stated range.
By their numbers in this assay, from the lowest: compound 3; then compounds 1 and 4 (each within the scatter of the next).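

At this place, on a carbonyl carbon whose other neighbour is an amide-type nitrogen, the series now has its first step between two measured compounds in this assay: bis(2-hydroxyethyl)amino in place of 2-phenylethenyl gives a 13-fold higher number from compound 3 to compound 4 (1.11 log units; beyond the scatter). The low number of compound 3 therefore depends on what sits on this carbonyl carbon and does not come from the rest of the molecule alone. The step is a composite one, though: a six-membered aromatic ring of carbon only and a double bond leave, while a group with no ring and with hydroxyethyl arms enters, and all of this is folded into a single number.

For the compounds shown here, compound 2 stays a limit and not a number, and no step leads to it: the limit of > 171000 nM in this assay, at which 1 of the 4 values shown sits. What remains open is which part of the exchange carries the step, for instance whether a plain phenyl without the double bond, a dimethylamino group or a single 2-hydroxyethyl chain on this carbonyl carbon would keep the number low or raise it.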